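Benzyl halogen swap on a pyrazole carboxamide: expected tolerance

The source may hold more compounds than are shown below. What is called first, only, known or untested is meant among the compounds shown, and "the series" means these compounds.

Measured compounds:
compound 1 `O=C(NOCc1ccccc1Cl)c1cn(-c2ccccc2)nc1-c1ccccc1` with 82100 nM
compound 2 `COc1ccc(-c2nn(-c3ccccc3)cc2C(=O)NOCc2ccccc2Cl)cc1` with 586000 nM
compound 3 `O=C(NOCc1ccccc1F)c1cn(-c2ccccc2)nc1-c1ccc(Cl)cc1` with 126000 nM

In an ADME assay on HEK-293T cells (Homo sapiens) for antiproliferative activity, read by MTT assay, with a stated time of 48 h, in the presence of a further agent that is not named here (a lower number here means that less compound is tolerated, a higher number that more compound is tolerated), compound 3 stands second highest of the three numbers, within the scatter of compound 1 and beyond it from compound 2, whose value is the highest. The unmeasured compound 4 `O=C(NOCc1ccccc1Cl)c1cn(-c2ccccc2)nc1-c1ccc(Cl)cc1` differs from compound 3 by chloro in place of fluoro on an aromatic carbon. Going by the values given here, the only measured step, a 7.1-fold higher number from compound 1 to compound 2 (0.85 log units; beyond the scatter), concerns a different group at a different place and does not bear directly on this change. Compound 1, which also carries a 2-chlorobenzyl group, lies within the scatter of compound 3 in this assay. He therefore expects no step beyond the scatter, a 1.1-fold lower number from compound 3 to compound 4 (0.06 log units; within the scatter). For compound 4 he estimates 110000 nM, in the range 50000 nM to 250000 nM.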

Compound 4, half-maximal cytotoxic concentration: 129000 nM
The estimate for compound 4 lay 1.2-fold (0.07 log units) below the measured number, within the range that was stated.
By their numbers in this assay, from the lowest: compounds 1, 3 and 4 (each within the scatter of the next); then compound 2.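

In this assay, the change from 2-fluorobenzyl to 2-chlorobenzyl gives a 1.0-fold higher number from compound 3 to compound 4 (0.01 log units; within the scatter) and so leaves the number unmoved at this position. Going by these compounds alone, on the other aromatic ring, chloro and hydrogen read alike in a 1.6-fold higher number from compound 1 to compound 4 (0.20 log units; within the scatter) while methoxy stands apart in a 4.5-fold lower number from compound 2 to compound 4 (0.66 log units; beyond the scatter) and so far is the only group there that shifts the number. No evidence is available to explain these steps.

As far as these compounds go, whether bromo or methyl on the benzyl group would be tolerated equally remains open. So does the effect of an amine or a carboxylic acid in place of the chloro on the other ring.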